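A smaller amine on the shared core: what to expect

The source may hold more compounds than are shown below. What is called first, only, known or untested is meant among the compounds shown, and "the series" means these compounds.

Measured in an assay on cells for activation of Cystic fibrosis transmembrane conductance regulator (Homo sapiens), read by fluorescence, with stated times of 10 min and 12 s; a higher number here means that more compound is needed for the effect, a lower number that less compound is needed:
compound 1 `CCN(CC)c1nc(Nc2ccccc2)nc(OCC(F)(F)C(F)F)n1`: 2000 nM
compound 2 `CCN(CC)c1nc(Nc2cccc(Cl)c2)nc(OCC(F)(F)C(F)F)n1`: 5400 nM
compound 3 `CCN(CC)c1nc(Nc2cccc([N+](=O)[O-])c2)nc(OCC(F)(F)C(F)F)n1`: 1200 nM

Compound 1 stands second highest of the three numbers. Compound 3 sits within the scatter of it (a 1.7-fold lower number from compound 1 to compound 3 (0.22 log units; within the scatter)), while compound 2 lies beyond it (a 2.7-fold higher number from compound 1 to compound 2 (0.43 log units; beyond the scatter)). Compound 4 `CNc1nc(Nc2ccccc2)nc(OCC(F)(F)C(F)F)n1` differs from compound 1 by methylamino in place of diethylamino on an aromatic carbon. Among the compounds with values here, none of the measured steps bears on this change: all three alter only the substituent on the anilino ring, and even the largest of them, a 4.5-fold lower number from compound 2 to compound 3 (0.65 log units; beyond the scatter), stays modest. With nothing measured on this side of the core, the expected step in this assay is small and uncertain; the estimate is a 1.3-fold higher number from compound 1 to compound 4 (0.10 log units; within the scatter). Compound 4 is therefore expected near 2500 nM, in the range 600 nM to 10000 nM.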

Compound 4, half-maximal effective concentration: 40 nM
Compound 4: the middle estimate sits 63-fold (1.80 log units) above what was measured, outside the stated range (below it).
By their numbers in this assay, from the lowest: compound 4; then compounds 3 and 1 (each within the scatter of the next); then compound 2.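

The side of the shared core that carries the amine matters more here than the anilino ring: in this assay, methylamino in place of diethylamino gives a 50-fold lower number from compound 1 to compound 4 (1.70 log units; beyond the scatter), a larger step than any seen among compound 1, compound 2 and compound 3. This change swaps a group of 5 heavy atoms and no hydrogen-bond donor for one of 2 heavy atoms and 1 hydrogen-bond donor. Nothing available explains the size of this step.

Going by these compounds, whether the smaller size or the added donor drives the drop stays open, and dimethylamino or ethylamino on the same carbon would help separate them. On these data alone, it is also open whether the chloro and nitro steps carry over to the methylamino series.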